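The source may report more compounds than this note shows. Statements on the series, on what has been measured and on what is new or still open speak of the compounds shown alone.

Measured so far:
compound 1 `Cc1ccc(CNc2ncnc3c2ncn3[C@@H]2O[C@H](CO)[C@@H](O)[C@H]2O)cc1` — a functional assay on HL-60 cells (Homo sapiens) for antiproliferative activity, with a stated time of 72 h; on this read-out higher numbers stand for weaker inhibition and lower numbers for stronger inhibition: > 166000 nM
compound 2 `COc1cc(CNc2ncnc3c2ncn3[C@@H]2O[C@H](CO)[C@@H](O)[C@H]2O)cc(OC)c1` — this assay : 20200 nM

Compound 1 stands only at a limit of this assay, (the limit of > 166000 nM in this assay, at which 1 of the 2 values shown sits), so no number is known for it. Compound 2 gives a measured number in this assay, 20200 nM. Among the measured compounds shown here, the one measured step runs between them: an at least 8.2-fold lower number from compound 1 to compound 2 (0.91 log units; beyond the scatter); it shows that exchanging the ring on the saturated chain carbon bound to the nitrogen on the aromatic ring can move the read-out well beyond the scatter.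

Compound 3 `OC[C@H]1O[C@@H](n2cnc3c(NCc4c(F)ccc(F)c4F)ncnc32)[C@H](O)[C@@H]1O` is not yet measured. Its change from compound 1: 2,3,6-trifluorophenyl in place of 4-methylphenyl on a saturated chain carbon bound to a nitrogen on an aromatic ring. For the measured compounds named here, the entering ring is not the one seen in compound 2, so the measured step from compound 1 to compound 2 bears on it only as a sign that this position is sensitive, not as a template for the size.

For compound 3 the expectation is a lower number than the limit of compound 1, by a step of an at least 2.7-fold lower number from compound 1 to compound 3 (0.44 log units; beyond the scatter), but with wide uncertainty. Compound 3 is therefore estimated at 60000 nM, within 15000 nM to 200000 nM, and a limit-only result remains possible.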

Compound 3, half-maximal inhibitory concentration: 13000 nM
The estimate for compound 3 lay 4.6-fold (0.66 log units) above the measured number; measured number below the stated range.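

In this assay, a second replacement of 4-methylphenyl on the saturated chain carbon bound to a nitrogen on an aromatic ring also gives a step beyond the scatter, an at least 12-fold lower number from compound 1 to compound 3 (1.10 log units; beyond the scatter), so the sensitivity of this position no longer rests on 3,5-dimethoxyphenyl alone. The two entering rings carry different substituents, methoxy groups on one and fluorine atoms on the other, yet the step between them, a 1.6-fold lower number from compound 2 to compound 3 (0.19 log units; within the scatter), lies within the scatter, so the series gives no order between compound 2 and compound 3. Compound 1 stands at a limit, so the steps that start from it give only a minimum size: the limit of > 166000 nM in this assay, at which 1 of the 3 values shown sits.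

The compounds shown do not separate the loss of 4-methylphenyl from the gain of either entering ring, and a plain unsubstituted phenyl ring would be the direct reference for that question. Also open, on these data alone, is how the read-out responds to a ring carrying an amine or a carboxylic acid, or to a longer chain between the ring and the nitrogen.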